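The source may hold more compounds than are shown below. What is called first, only, known or untested is meant among the compounds shown, and "the series" means these compounds.

Notes on the series. Compound 1 `CC1CCN(c2ccc(Nc3ncc4c(n3)N(C3CCCC3)CC(=O)N4)cc2)CC1` and compound 3 `CC1CCN(c2ccc(Nc3ncc4c(n3)N(C3CCCC3)CC(=O)N4C)cc2)CC1` share one core; compound 3 carries methyl in place of hydrogen on an amide-type nitrogen in a ring. Compound 2 `CN1CCN(c2ccc(Nc3ncc4c(n3)N(C3CCCC3)CC(=O)N4)nc2)CC1` stands on another core, and the difference between the two cores is not broken down here. Compound 4 `CN1CCN(c2ccc(Nc3ncc4c(n3)N(C3CCCC3)CC(=O)N4C)nc2)CC1` is not yet measured; relative to compound 2 it carries methyl in place of hydrogen on an amide-type nitrogen in a ring, the same change as that from compound 1 to compound 3.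

In a functional assay on HeLa cells (Homo sapiens) for inhibition, read by MTT assay, with a stated time of 48 h (a higher number here means a weaker inhibitor, a lower number a stronger inhibitor), compound 1 gives only a limit, > 30000 nM. Compound 3 likewise gives only a limit in this assay, > 30000 nM. For compound 2 this assay again reports only a limit, > 30000 nM. The step that the two limits leave unreadable from compound 1 to compound 3 cannot be read, because the limit of > 30000 nM in this assay, at which 3 of the 3 values shown sit, holds every value shown.

Given the step that the two limits leave unreadable from compound 1 to compound 3, compound 4 is expected to remain at 40000 nM in this assay. For compound 4 this means an expected step that the limit leaves unreadable from compound 2 to compound 4, most likely reported once more as a limit rather than a number.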

Compound 4, half-maximal inhibitory concentration: 13100 nM
Compound 4: middle estimate off by 3.1-fold (0.48 log units), on the high side; the measured number lies below the stated range.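

In this assay, methyl in place of hydrogen on an amide-type nitrogen in a ring gives an at least 2.2-fold lower number from compound 2 to compound 4 (0.35 log units; beyond the scatter), so on the core of compound 2 the change goes with a lower number, beyond the scatter. The matching step from compound 1 to compound 3 cannot be read, so neither agreement nor disagreement between the two cores can be claimed, because both of its ends sit at a limit: the limit of > 30000 nM in this assay, at which 3 of the 4 values shown sit. On these data alone, for compound 2 the value > 30000 nM is a limit and not a number, so the full size of the step stays unknown, and one readable step does not show that the change carries from one core to the other.

The compounds shown leave open whether an ethyl group or a longer chain on that same nitrogen would give a lower or a higher number than methyl. They also leave open which part of the difference between the two cores goes with the readable step, as no comparison in one place links compound 4 to compound 3.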